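Swapping the benzamide aryl group on a thiophene carboxamide core

The source may hold more compounds than are shown below. What is called first, only, known or untested is meant among the compounds shown, and "the series" means these compounds.

Measured so far:
- Compound 1 `NC(=O)c1c(NC(=O)c2ccccc2F)sc2c1CCN(C(=S)Nc1ccccc1Cl)C2` gives 11100 nM in a functional assay on MKN-74 cells (Homo sapiens) for antiproliferative activity, with a stated time of 24 h; a higher number here means a weaker inhibitor, a lower number a stronger inhibitor.
- Compound 2 `CSc1ccccc1C(=O)Nc1sc2c(c1C(N)=O)CCN(C(=S)Nc1ccccc1Cl)C2` gives 6550 nM in this assay.

Within the data shown here, compound 2 has the lower of the two numbers, but its only neighbour, compound 1, lies close: a 1.7-fold lower number from compound 1 to compound 2 (0.23 log units; within the scatter). On the numbers shown, compound 2 is therefore not separated from compound 1 in this assay.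

Compound 3 `Cc1ccc(C(=O)Nc2sc3c(c2C(N)=O)CCN(C(=S)Nc2ccccc2Cl)C3)cc1` has not been measured. It differs from compound 2 in one place: 4-methylphenyl in place of 2-(methylsulfanyl)phenyl on a carbonyl carbon. Among the measured compounds shown here, the only measured step, from compound 1 to compound 2, exchanged one group on this same aromatic ring for another and stayed within the scatter. For the measured compounds named here, there is no measured step that exchanges this ring for a 4-methylphenyl ring, so nothing in the data points to a change in either direction beyond the scatter. The expectation for compound 3 in this assay is therefore a number near that of compound 2, with a wide range on both sides.

Compound 3 is estimated at 8000 nM in this assay, with a range from 3000 nM to 25000 nM, which means an expected step of a 1.2-fold higher number from compound 2 to compound 3 (0.09 log units; within the scatter).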

Compound 3, half-maximal inhibitory concentration: 11300 nM
The estimate for compound 3 lay 1.4-fold (0.15 log units) below the measured number; low and high end bracket the measured number.
By their numbers in this assay, from the lowest: compounds 2, 1 and 3 (each within the scatter of the next).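

In this assay the swap to 4-methylphenyl on the carbonyl carbon gives a 1.7-fold higher number from compound 2 to compound 3 (0.24 log units; within the scatter) and the swap from 2-fluorophenyl to the same group gives a 1.0-fold higher number from compound 1 to compound 3 (0.01 log units; within the scatter) as the two new readings at this position. Among these compounds, the position now carries three different aryl groups, and no step among compound 1, compound 2 and compound 3 leaves the scatter, so the numbers do not separate these groups. This also holds for a change that takes out the sulfur of the 2-(methylsulfanyl)phenyl group and with it the one hydrogen-bond acceptor counted in that group, so neither appears to be needed for a number in this range among these compounds. No measurement is at hand that could explain these numbers.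

From the compounds shown here alone, all three groups are six-membered aromatic rings of carbon only, so it stays open whether a ring bearing an amine or a carboxylic acid, or a longer chain in place of the ring, would move the number beyond the scatter. The rest of the shared core stays the same in all three compounds, so these steps say nothing about changes made elsewhere on it.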